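Aryl amide variation on a pyridine N-oxide piperidine series

The source may report more compounds than this note shows. Statements on the series, on what has been measured and on what is new or still open speak of the compounds shown alone.

Measured so far:
compound 1 `O=C(CN1CCC(c2cccc[n+]2[O-])CC1)Nc1cccc(Cl)c1`, 62 nM
compound 2 `Cc1cc(F)ccc1NC(=O)CN1CCC(c2cccc[n+]2[O-])CC1`, 60 nM

Among the measured compounds shown here, in a functional assay on HEK293 cells for agonist activity at D(4) dopamine receptor (Homo sapiens), read by FLIPR (a lower number here means that less compound is needed, a higher number that more compound is needed for the effect), compound 1 gives 62 nM, the higher of the two numbers known, while compound 2 gives 60 nM. For the measured compounds named here, the one measured step, a 1.0-fold lower number from compound 1 to compound 2 (0.01 log units; within the scatter), changes the whole aryl group on the amide nitrogen without moving the number beyond the scatter. Compound 3 `O=C(CN1CCC(c2cccc[n+]2[O-])CC1)Nc1cccc(C(F)(F)F)c1` differs from compound 1 by trifluoromethyl in place of chloro on an aromatic carbon. Going by the values given here, no measured step alters only this substituent, so the aryl swap is the sole guide, and it suggests the amide-side aryl tolerates change. For compound 3 the expected step is a 1.1-fold higher number from compound 1 to compound 3 (0.05 log units; within the scatter), none beyond the scatter. Compound 3 is therefore estimated at 70 nM, within 30 nM to 160 nM.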

Compound 3, half-maximal effective concentration: 76 nM
The estimate for compound 3 lay 1.1-fold (0.04 log units) below the measured number, within the range that was stated.
By their numbers in this assay, from the lowest: compounds 2, 1 and 3 (each within the scatter of the next).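

At the aromatic carbon that carries chloro in compound 1, trifluoromethyl enters with more heavy atoms, and in this assay the step is a 1.2-fold higher number from compound 1 to compound 3 (0.09 log units; within the scatter). Among the compounds shown here, this is the first change of a single substituent, whereas the earlier step replaced the whole aryl group, and it too stays within the scatter. No available evidence bears on this result.

As far as these compounds go, whether an amine or a carboxylic acid at this carbon would also stay within the scatter remains open. Also open, from the compounds shown here alone, is how the number responds to changes in the shared core.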